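A few compounds are considered here, and "the series" means these few. Any claim that something is new, unique, unknown or untested is made for them only; others in the source may bear on it.

Working notes on the series. Compound 1 `C[C@@H](O[C@H]1CN2C(=O)C=C(c3ccc(C#N)cc3)CC2[C@@H]1c1ccc(F)cc1)c1cc(C(F)(F)F)cc(C(F)(F)F)c1` gives 1.8 nM in an assay on CHO cells for displacement of a labelled ligand from Substance-P receptor (Homo sapiens); on this read-out higher numbers stand for weaker inhibition and lower numbers for stronger inhibition. Compound 2 `C[C@@H](O[C@H]1CN2C(=O)C=C(c3ccc(NS(C)(=O)=O)cc3)CC2[C@@H]1c1ccc(F)cc1)c1cc(C(F)(F)F)cc(C(F)(F)F)c1` gives 1 nM in this assay and so has the lowest of the two numbers seen so far; the step of a 1.8-fold lower number from compound 1 to compound 2 (0.26 log units; within the scatter) is, however, within the scatter, so the two compounds cannot be ordered on these data. Compound 3 `Cc1cc(C2=CC(=O)N3C[C@H](O[C@H](C)c4cc(C(F)(F)F)cc(C(F)(F)F)c4)[C@@H](c4ccc(F)cc4)C3C2)ccn1` carries a different group at the same place: 2-methylpyridin-4-yl in place of 4-(methanesulfonamido)phenyl on a double-bonded ring carbon. Among the compounds with values here, the one measured step that bears on this position, a 1.8-fold lower number from compound 1 to compound 2 (0.26 log units; within the scatter), shows that exchanging the group on that double-bonded ring carbon left the number unchanged beyond the scatter; no measured step involves a pyridine at this place, so the bearing is indirect. The expectation is therefore a step in this assay of about a 2.0-fold higher number from compound 2 to compound 3 (0.30 log units; within the scatter), not clearly beyond the scatter in either direction. For compound 3 the estimate in this assay is 2 nM, with a range from 0.6 nM to 8 nM.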

Compound 3, half-maximal inhibitory concentration: 0.51 nM
Estimate against measurement, compound 3: 3.9-fold (0.59 log units) above; the measured number lies below the stated range.
By their numbers in this assay, from the lowest: compounds 3, 2 and 1 (each within the scatter of the next, the first and the last beyond it).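

In this assay, exchanging the group on this double-bonded ring carbon now gives a step beyond the scatter, though a modest one: a 3.5-fold lower number from compound 1 to compound 3 (0.55 log units; beyond the scatter) with 2-methylpyridin-4-yl in place of 4-cyanophenyl. Against 4-(methanesulfonamido)phenyl, the same group gives a 2.0-fold lower number from compound 2 to compound 3 (0.29 log units; within the scatter) so compound 2 and compound 3 cannot be ordered, and the place accepts a six-membered aromatic ring with a hetero atom and no hydrogen-bond donor without a loss beyond the scatter. No measured information on these compounds accounts for these differences.

The compounds shown leave open whether the step from 4-cyanophenyl follows the ring nitrogen or the methyl group of 2-methylpyridin-4-yl. Also open, going by these compounds, is how an unsubstituted phenyl, a pyridin-4-yl without the methyl group, or a phenyl carrying an aminomethyl group would read at this place.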